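The source may hold more compounds than are shown below. What is called first, only, known or untested is meant among the compounds shown, and "the series" means these compounds.

Compound 1 `CC(C)c1nnc(-c2ccc(N3CCC(Oc4ccccc4C(F)(F)F)CC3)nn2)s1`: in an assay on microsomes from liver for inhibition of acyl-CoA desaturase 1 (Rattus norvegicus) (on this read-out higher numbers stand for weaker inhibition and lower numbers for stronger inhibition), compound 1 gives 8.8 nM.
Compound 2 `FC(F)(F)c1ccc(OC2CCN(c3ccc(-n4ccnc4)nn3)CC2)cc1`: in this assay compound 2 gives 371 nM.
Compound 3 `COc1ccccc1OC1CCN(c2ccc(-n3ccnc3)nn2)CC1`: in this assay compound 3 gives 543 nM.

Compound 3 has the highest of the three numbers. Its value and that of compound 2 lie within the scatter of each other, so nothing separates them; compound 1, by contrast, sits far lower, well beyond the scatter. Compound 4 `c1cc(OC2CCN(c3ccc(-n4ccnc4)nn3)CC2)c2cc[nH]c2c1` has not been measured. It differs from compound 3 in one place: 1H-indol-4-yl in place of 2-methoxyphenyl on an oxygen on a saturated carbon. Going by the values given here, no measured pair shows this change, so its effect is unknown. A step from compound 3 to compound 4 of about a 1.4-fold lower number from compound 3 to compound 4 (0.13 log units; within the scatter) is expected, that is, none beyond the scatter in either direction. For compound 4 in this assay the estimate is 400 nM, within 100 nM to 1600 nM.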

Compound 4, half-maximal inhibitory concentration: 162 nM
Beside the measured number, compound 4's estimate is 2.5-fold (0.39 log units) above it; measured number inside the range.
By their numbers in this assay, from the lowest: compound 1; then compound 4; then compounds 2 and 3 (each within the scatter of the next).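

In this assay, going by these compounds alone, replacing 2-methoxyphenyl with 1H-indol-4-yl gives a 3.4-fold lower number from compound 3 to compound 4 (0.53 log units; beyond the scatter), the first measured step at this place, on an oxygen on a saturated carbon. It shows that the number here can respond to the group carried on that oxygen, with the two-ring 1H-indol-4-yl group on the lower side. Nothing measured explains the step. From the compounds shown here alone, it remains open whether the step depends on the hydrogen-bond donor that enters with 1H-indol-4-yl, which 1-methyl-1H-indol-4-yl would test, and whether it carries over to the core of compound 1.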